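Removing one methoxy group: compounds 1 to 4

This account rests on a few compounds, and the source may have more. Where it says the series, first, only, none or still open, it means among the compounds named here.

In a functional assay on K562 cells (Homo sapiens) for inhibition, read by sulforhodamine B assay, with a stated time of 48 h (on this read-out lower numbers stand for higher toxicity in this test and higher numbers for lower toxicity in this test), the measured compounds stand as follows.
Compound 1 `COc1ccc(-c2cc(/C=C/C(=O)c3ccc(N)cc3)[nH]n2)cc1` gives 69700 nM.
Compound 2 `COc1ccc(-c2cc(/C=C/C(=O)c3ccc(N)cc3)[nH]n2)cc1OC` gives > 100000 nM, which is a limit of this assay and not a number.
Compound 3 `COc1cc(C(=O)/C=C/c2cc(-c3cc(OC)c(OC)c(OC)c3)n[nH]2)cc(OC)c1OC` gives > 100000 nM, which is likewise a limit of this assay.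

Compound 2 and compound 1 differ in one place, (hydrogen in place of methoxy on an aromatic carbon), and this change gave an at least 1.4-fold lower number from compound 2 to compound 1 (0.15 log units; that floor lies within the scatter). Two of the three values sit at the limit, as shown by the limit of > 100000 nM in this assay, at which 2 of the 3 values shown sit, so the size of that step is open-ended. The cores of compound 2 and compound 3 differ in more than one place; the difference between the two cores is not broken down here. Compound 4 `COc1ccc(-c2cc(/C=C/C(=O)c3cc(OC)c(OC)c(OC)c3)[nH]n2)cc1OC` has not yet been measured in this assay. It differs from compound 3 by hydrogen in place of methoxy on an aromatic carbon, the same kind of change as from compound 2 to compound 1; around the place the difference is that in compound 3 the leaving methoxy is also meta to a methoxy group. For compound 4 a step like the earlier one is expected, an at least 1.4-fold lower number from compound 3 to compound 4 (0.15 log units; that floor lies within the scatter), resting on an at least 1.4-fold lower number from compound 2 to compound 1 (0.15 log units; that floor lies within the scatter) and on the limit at which compound 3 stands. Compound 4 is therefore expected near 70000 nM, within 35000 nM to 200000 nM.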

Compound 4, concentration lethal to 50% of the cells: > 100000 nM
Compound 4 ended at the assay's limit; the forecaster's own chance of this, stated with the estimate: 40%; middle value at least 1.4-fold (0.15 log units) away from the limit.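

In this assay, compound 3 and compound 4 both sit at a limit and not at a number, so no step between them can be read: the limit of > 100000 nM in this assay, at which 3 of the 4 values shown sit.

The compounds shown leave open how large the change from methoxy to hydrogen on an aromatic carbon really is, as only compound 1 carries an actual number.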